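Sulfamoylphenyl in place of pyridine carboxamide on the biaryl tail

The source may report more compounds than this note shows. Statements on the series, on what has been measured and on what is new or still open speak of the compounds shown alone.

Compound 1 `N=C(N)c1ccc(O)c(/C=C/CNC(=O)c2ccc(-c3ccc(C(N)=O)cc3)cc2)c1` gives 1400 nM in an assay on isolated protein for inhibition of serine protease 1 (Homo sapiens); a higher number here means a weaker inhibitor, a lower number a stronger inhibitor; compound 2 `N=C(N)c1ccc(O)c(/C=C/CNC(=O)c2ccc(-c3ccnc(C(N)=O)c3)cc2)c1` gives 2200 nM, the higher of the two numbers. Going by the values given here, the only measured step is a 1.6-fold higher number from compound 1 to compound 2 (0.20 log units; within the scatter), where one terminal ring carrying a carboxamide was exchanged for another. Compound 3 `N=C(N)c1ccc(O)c(/C=C/CNC(=O)c2ccc(-c3ccc(S(N)(=O)=O)cc3)cc2)c1` carries 4-sulfamoylphenyl in place of 2-carbamoylpyridin-4-yl on an aromatic carbon, on an aromatic carbon para to a large group. With that single step within the scatter, no shift beyond the scatter is expected in this assay, and compound 3 is estimated at 1500 nM (range 500 nM to 4500 nM), meaning an expected step of a 1.5-fold lower number from compound 2 to compound 3 (0.17 log units; within the scatter).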

Compound 3, inhibition constant: 1600 nM
The estimate for compound 3 lay 1.1-fold (0.03 log units) below the measured number; the range from low to high includes it.
By their numbers in this assay, from the lowest: compounds 1, 3 and 2 (each within the scatter of the next).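

In this assay the exchange of 2-carbamoylpyridin-4-yl for 4-sulfamoylphenyl gives a 1.4-fold lower number from compound 2 to compound 3 (0.14 log units; within the scatter) and the exchange of carbamoyl for sulfamoyl on an aromatic carbon gives a 1.1-fold higher number from compound 1 to compound 3 (0.06 log units; within the scatter) with both steps within the scatter. The earlier pair varied only the ring bearing a carboxamide, whereas this place now also accepts a sulfamoyl with no readable change in this assay. On these data alone, whether an amine or a carboxylic acid here would give a step beyond the scatter remains open. No measurement at hand explains why these groups read alike.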